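Lipidated Cysteine Amides: A Tertiary Amine Tail

The source may report more compounds than this note shows. Statements on the series, on what has been measured and on what is new or still open speak of the compounds shown alone.

This account concerns a pair of measured lipidated cysteine amides and a third, untested one. In an assay on HEK293 cells for agonist activity at Toll-like receptor 2 (Homo sapiens) (a higher number here means that more compound is needed for the effect, a lower number that less compound is needed), compound 1 `CCCCCCCCCCCC(=O)OC[C@H](CSC[C@@H](N)C(=O)NC(C)(C)CO)OC(=O)CCCCCCCCCCC` gives 15500 nM. Compound 2 `CCCCCCCCCCCC(=O)OC[C@H](CSC[C@@H](N)C(=O)NCCCCN)OC(=O)CCCCCCCCCCC` gives 1040 nM in this assay, the lowest of the two numbers shown, and the only step in the set, a 15-fold lower number from compound 1 to compound 2 (1.17 log units; beyond the scatter), separates it from compound 1.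

Compound 3 `CCCCCCCCCCCC(=O)OC[C@H](CSC[C@@H](N)C(=O)NC(C)CCN(CC)CC)OC(=O)CCCCCCCCCCC` differs from compound 2 by 3-(diethylamino)-1-methylpropyl in place of 4-aminobutyl on an amide-type nitrogen. For the measured compounds named here, no measured step matches this change directly. Going by the values given here, the one step available, from compound 1 to compound 2, concerned the same amide-type nitrogen and was large, so this position clearly matters in this assay, but it exchanged a hydroxyl-bearing branched group for an amine-bearing chain, whereas here the amine is kept in a different form and the donor count falls. The size of the step cannot be read from that precedent.

Compound 3 is therefore expected to land near compound 2, with a step of a 2.9-fold higher number from compound 2 to compound 3 (0.46 log units; beyond the scatter) considered most likely, and an estimated value of 3000 nM, within a range from 800 nM to 12000 nM.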

Compound 3, half-maximal effective concentration: 257 nM
Compound 3: middle estimate off by 12-fold (1.07 log units), on the high side; measured number outside the range, below it.
By their numbers in this assay, from the lowest: compound 3; then compound 2; then compound 1.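

With a 4.0-fold lower number from compound 2 to compound 3 (0.61 log units; beyond the scatter) in this assay, the group on the amide-type nitrogen turns out not to need a hydrogen-bond donor: 3-(diethylamino)-1-methylpropyl counts 0 hydrogen-bond donors against 1 for 4-aminobutyl, and the number still fell. Set against 1-(hydroxymethyl)-1-methylethyl, the same group gives a 60-fold lower number from compound 1 to compound 3 (1.78 log units; beyond the scatter), so the span seen at this one position is wider than the earlier compounds showed, and the amine-bearing groups of compound 2 and compound 3 both lie well under the hydroxyl-bearing group of compound 1. Nothing in hand explains why the number fell, and the result stands as an observation only.

The compounds shown leave open whether the lower number follows the two ethyl groups on the amine, the methyl branch or the larger group as a whole, which all enter together in compound 3. An unbranched 4-(diethylamino)butyl group would separate the branch from the ethyl groups, and a carboxylic acid in place of the amine would ask whether an amine is needed on this chain at all.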